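The compounds below may be only part of what the source reports. "The series", "measured", "known", "first", "only" and "open" are said of these compounds alone.

Measured so far in a physicochemical assay for lipophilicity, at pH 7.4; a lower number here means a more polar compound, a higher number a more lipophilic compound:
compound 1 `Cc1cc(C(=O)O)nn1C(C)c1cc(Cl)ccc1OCc1ccccc1` — 1
compound 2 `Cc1cc(C(=O)NCc2cccnc2)nn1Cc1cc(Cl)ccc1OCc1ccccc1` — > 3.7
compound 3 `Cc1cc(C(=O)NN2CCOCC2)nn1Cc1cc(Cl)ccc1OCC(C)C` — 3.1

Compound 2 stands at the limit of > 3.7 in this assay, at which 1 of the 3 values shown sits; only a limit is known for it, not a number. Compound 4 `Cc1cc(NC(=O)OCC(C)C)nn1Cc1cc(Cl)ccc1OCc1ccccc1` differs from compound 2 in one place: (isobutoxycarbonyl)amino in place of ((pyridin-3-yl)methyl)carbamoyl on an aromatic carbon. Going by the values given here, no step between two measured compounds covers a change of this kind, so the size of the step can only be expected, not read off. A rise in this assay is expected, or at most none beyond the scatter, since compound 2 already sits at a limit. The step from compound 2 to compound 4 is expected to be a step that the limit leaves unreadable from compound 2 to compound 4. Compound 4 is estimated at 4.2, between 3.6 and 4.8.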

Compound 4, distribution coefficient: 3.3
Compound 4: the middle estimate sits 0.90 log units above what was measured; the whole stated range lies above it.
By their numbers in this assay, from the lowest: compound 1; then compounds 3 and 4 (each within the scatter of the next). At a limit, above all of these: compound 2.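

In this assay, going by these compounds alone, (isobutoxycarbonyl)amino in place of ((pyridin-3-yl)methyl)carbamoyl at this position gives a number at least 0.40 log units lower from compound 2 to compound 4 (beyond the scatter), the first step that differs in one place. The value of compound 2, > 3.7, is a limit and not a number. From the compounds shown here alone, the step's full size therefore remains unknown, though it comes with unchanged counts of hydrogen-bond donors and acceptors while the six-membered aromatic ring leaves.

Going by these compounds, whether the loss of that ring or the change of linking atoms carries the step remains open. An amine or a longer chain at this position is not covered by the compounds shown.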